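This account rests on a few compounds, and the source may have more. Where it says the series, first, only, none or still open, it means among the compounds named here.

Measured in a functional assay on MCF7 cells (Homo sapiens) for cytotoxicity, read by MTT assay, with a stated time of 3 days; a lower number here means a stronger inhibitor, a higher number a weaker inhibitor:
compound 1 `Nc1ccccc1-c1ccccc1O` gives 56 ug/mL
compound 2 `COc1ccccc1-c1cccc(O)c1` gives 44 ug/mL

Compound 2 shows the smaller of the two numbers, but compound 1 lies within the scatter of it, so the two are not separated in this assay. Compound 3 `Nc1ccccc1-c1cccc(O)c1` is compound 2 with amino in place of methoxy on an aromatic carbon. Going by the values given here, no pair of measured compounds isolates this change, so nothing sets its size. The expected step from compound 2 to compound 3 in this assay is a 1.1-fold higher number from compound 2 to compound 3 (0.06 log units; within the scatter), that is, none beyond the scatter in either direction. Compound 3 is therefore estimated at 50 ug/mL, with a range of 20 ug/mL to 120 ug/mL.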

Compound 3, half-maximal inhibitory concentration: 16 ug/mL
Compound 3: the middle estimate sits 3.1-fold (0.49 log units) above what was measured; measured number below the stated range.
By their numbers in this assay, from the lowest: compound 3; then compounds 2 and 1 (each within the scatter of the next).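

In this assay, going by these compounds alone, amino in place of methoxy on the aromatic carbon gives a 2.8-fold lower number from compound 2 to compound 3 (0.44 log units; beyond the scatter) and is the first measured single-place change, with a size beyond the scatter. This position, ortho to a group of 7 heavy atoms, therefore responds to the identity of its substituent, which compound 1 and compound 2 could not show. No supporting data bear on why the number falls.

Open, on these data alone, is whether a dimethylamino or acetamido group on this carbon keeps the lower number of compound 3. Also open, as far as these compounds go, is whether a smaller group such as fluorine does the same.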